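Chloro Enters the Anilide of a Low-Activity Oxalamide

The compounds below may be only part of what the source reports. "The series", "measured", "known", "first", "only" and "open" are said of these compounds alone.

Compound 1 `Cc1cc(OCCCS(C)(=O)=O)cc(C)c1-c1cccc(COc2ccc(OCC(=O)O)c(F)c2)c1` and compound 2 `O=C(O)COc1ccc(NC(=O)C(=O)Nc2ccccc2)cc1F` were both tested in a functional assay on CHO cells for agonist activity at Free fatty acid receptor 1 (Homo sapiens), read by FLIPR, tested at 300 nM; on this read-out higher numbers stand for a stronger effect at the one concentration tested and lower numbers for a weaker effect. In this assay compound 1 gives 67.3%, while compound 2 gives 26.5%, the lower of the two numbers and beyond the scatter below compound 1. Compound 3 `O=C(O)COc1ccc(NC(=O)C(=O)Nc2ccccc2Cl)cc1F` is not yet measured. It differs from compound 2 by a single change: chloro in place of hydrogen on an aromatic carbon. Within the data shown here, no measured pair shows what this change does, so compound 3 is expected to stay close to compound 2, with a step of a number 5.5 percentage points higher from compound 2 to compound 3 (within the scatter) that need not exceed the scatter. The estimated activity of compound 3 is 32%, within 14% to 55%.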

Compound 3, a percentage reported as activity, at one concentration (the size of the read-out at that concentration, not a potency): 27.9%
Compound 3: middle estimate off by 4.1 percentage points, on the high side; the range from low to high includes it.
By their numbers in this assay, from the lowest: compounds 2 and 3 (each within the scatter of the next); then compound 1.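

In this assay, chloro in place of hydrogen on an aromatic carbon, ortho to a large group, gives a number 1.4 percentage points higher from compound 2 to compound 3 (within the scatter). Among these compounds, this is the first reading of any change at this position, and it shows that a single chlorine atom here leaves the read-out within the scatter. Nothing measured here bears on the reason for this result.

From the compounds shown here alone, whether a methoxy group, an amine or a longer chain on the same carbon would also stay within the scatter remains open. So does the outcome of chloro on the other carbons of this ring.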